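The source may hold more compounds than are shown below. What is called first, only, known or untested is meant among the compounds shown, and "the series" means these compounds.

Measured in an ADME assay on MRC5 cells (Homo sapiens) for cytotoxicity, read by MTT assay, with a stated time of 72 h; a lower number here means a stronger inhibitor, a higher number a weaker inhibitor:
- compound 1 `O=C(Nc1nnc(-c2cccc(O)c2O)s1)c1ccc(Cl)cc1`: 18700 nM
- compound 2 `Cc1ccc(C(=O)Nc2nnc(-c3ccc(O)c(O)c3)s2)cc1`: 27100 nM

Compound 1 at 18700 nM lies within the scatter of compound 2, so these two values set no order between them. Among the compounds with values here, neither do they form a single-change step, so no measured step gauges the next change.

Compound 3 `CC(=O)Nc1nnc(-c2cccc(O)c2O)s1` keeps the core of compound 1 and has methyl in place of 4-chlorophenyl on a carbonyl carbon.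

In this assay, a move to a higher number, beyond the scatter but not large, is expected. This expectation rests only on the size of the structural change and on the narrow span of the two measured values, so it is weakly supported. The expected size is a 2.4-fold higher number from compound 1 to compound 3 (0.38 log units; beyond the scatter). For compound 3 the estimated value is 45000 nM, with an expected range of 15000 nM to 130000 nM.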

Compound 3, half-maximal inhibitory concentration: 156000 nM
Estimate against measurement, compound 3: 3.5-fold (0.54 log units) below; measured number outside the range, above it.
By their numbers in this assay, from the lowest: compounds 1 and 2 (each within the scatter of the next); then compound 3.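

Methyl in place of 4-chlorophenyl on a carbonyl carbon gives an 8.3-fold higher number from compound 1 to compound 3 (0.92 log units; beyond the scatter) in this assay, which is the first single-change step in the series and lies beyond the scatter. The number therefore depends on the group at this position and is not set by the shared core alone: the core of compound 1 is kept in compound 3, which reads 156000 nM. No measurement bears on why the step arises.

From the compounds shown here alone, it remains open whether the step follows the six-membered aromatic ring or the chlorine on it, and how a plain phenyl, a cyclohexyl or a longer chain on the same carbonyl carbon would read. Compound 2 differs from compound 1 in more than one place, so it cannot settle either question.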